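Chloro in place of methoxy on the pendant ring

The source may hold more compounds than are shown below. What is called first, only, known or untested is meant among the compounds shown, and "the series" means these compounds.

Measured in a functional assay on the whole organism for inhibition, with Rattus norvegicus as the target, at a dose of 30 mg/kg; a higher number here means more inhibition at the dose given (going by the name of the read-out), a lower number less inhibition:
compound 1 `COc1ccc(Br)c(-c2nc3ncccc3o2)c1`: 8%
compound 2 `Clc1ccccc1-c1nc2ncccc2o1`: 38%
compound 3 `COc1cccc(-c2nc3ncccc3o2)c1`: 14%

Compound 3 stands second highest of the three numbers in this assay; compound 1 lies within the scatter of it, while compound 2 lies beyond the scatter above it. Within the data shown here, the only single-change step measured, a number 6 percentage points higher from compound 1 to compound 3 (within the scatter), concerns a bromo group and not the change at hand. Compound 4 `Clc1cccc(-c2nc3ncccc3o2)c1` differs from compound 3 by chloro in place of methoxy on an aromatic carbon. Among the measured compounds shown here, compound 2 also carries a chloro group, and compound 2 gives 38% against compound 3 at 14%, but no single-change step joins them, so nothing measured bears directly on this change. The expected step of a number 8 percentage points higher from compound 3 to compound 4 (within the scatter) is therefore small and uncertain, leaning upward. Compound 4 is expected to give 22%, between 5% and 45%.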

Compound 4, a percentage reported as inhibition, in the whole organism at one dose (the size of the read-out at that dose, not a potency): 32%
The estimate for compound 4 lay 10 percentage points below the measured number, within the range that was stated.
By their numbers in this assay, from the lowest: compounds 1 and 3 (each within the scatter of the next); then compounds 4 and 2 (each within the scatter of the next).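

In this assay, among these compounds, chloro in place of methoxy on this aromatic carbon gives a number 18 percentage points higher from compound 3 to compound 4 (beyond the scatter) and is the first step to lie beyond the scatter. The place meta to a group of 9 heavy atoms therefore responds to a change of group, which the bromo step did not show. Nothing measured accounts for this gain.

As far as these compounds go, whether the gain follows from losing methoxy or from gaining chloro remains open. Hydrogen, fluoro or an amine on this carbon would help separate the two.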